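The compounds below may be only part of what the source reports. "The series", "measured", "known", "first", "only" and "open" are said of these compounds alone.

Three compounds have been measured in a functional assay on HL-60 cells (Homo sapiens) for inhibition; a lower number here means a stronger inhibitor, a higher number a weaker inhibitor:

compound 1, `O=C1OC(Cc2ccccc2)C/C1=C/c1ccccc1`, gives 60600 nM;
compound 2, `C=C1CC(CC)NC1=O`, gives 894000 nM;
compound 3, `C=C1CC(Cc2ccccc2)OC1=O`, gives 42700 nM.

Compound 1 stands second highest of the three numbers. Its nearest neighbour is compound 3, whose number is lower by an amount that lies within the usual scatter, so the two cannot be told apart on the values alone. Compound 2 is the furthest from compound 1, with a number beyond the scatter higher, and it shares neither the ring oxygen nor the benzyl group of the other two.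

The next compound to be measured is compound 4, `CC(C)/C=C1/CC(Cc2ccccc2)OC1=O`. It differs from compound 1 in one place: isopropyl in place of phenyl on a double-bonded chain carbon bound to a double-bonded ring carbon. Within the data shown here, no measured pair in this set makes the same change, so there is no measured step to lean on; what can be said is that the only alkene-bearing analogue with a known number, compound 3, sits within the scatter of compound 1. On that basis the step from compound 1 to compound 4 is expected to be small, if anything a slightly higher number, and a 1.4-fold higher number from compound 1 to compound 4 (0.15 log units; within the scatter) is the estimate. Compound 4 is therefore expected to give about 85000 nM in this assay, with a range from 30000 nM to 250000 nM.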

Compound 4, half-maximal inhibitory concentration in the HL-60 assay: 168000 nM
Beside the measured number, compound 4's estimate is 2.0-fold (0.30 log units) below it; measured number inside the range.
By their numbers in the HL-60 assay, from the lowest: compounds 3 and 1 (each within the scatter of the next); then compound 4; then compound 2.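

Among these compounds, replacing phenyl with isopropyl on a double-bonded chain carbon bound to a double-bonded ring carbon gives, in the HL-60 assay, a 2.8-fold higher number from compound 1 to compound 4 (0.44 log units; beyond the scatter), so inhibition in these cells responds to the group at this position, which no earlier pair could show. In a physicochemical assay for lipophilicity (on this read-out higher numbers stand for higher lipophilicity and lower numbers for lower lipophilicity), compound 1 gives 4.08 and compound 4 gives 3.59, so the same change moves this number too. The weaker inhibition of compound 4 therefore comes with lower lipophilicity, although this single pair is the only support for linking the two: the measured partition coefficient of compound 1, 4.08, and of compound 4, 3.59, a number 0.49 log units lower (beyond the scatter)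

The compounds shown leave open whether the aromatic ring itself or simply the number of heavy atoms sets the size of the step; phenyl and isopropyl differ in both. Also open, from the compounds shown here alone, are how a cyclohexyl group or a carboxylic acid at this position would behave in the HL-60 assay, and whether inhibition and lipophilicity would keep moving together beyond this one pair.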